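Heteroaryl amide swaps on the shared core

The source may report more compounds than this note shows. Statements on the series, on what has been measured and on what is new or still open speak of the compounds shown alone.

The series holds a shared core, seen in compound 1 `CCCCCCCCCCCC[C@@H](O)[C@H]1CC[C@H]([C@H](O)CCCCCCCCCCNC(=O)c2ccoc2)O1`, carrying an amide whose aromatic part is varied. In a functional assay (RXF 631 cells, Homo sapiens) for inhibition, read by colorimetric assay and sulforhodamine B assay, with a stated time of 48 h (a higher number here means a weaker inhibitor of growth, a lower number a stronger inhibitor of growth), compound 1 gives 100000 nM. Compound 2 `CCCCCCCCCCCC[C@@H](O)[C@H]1CC[C@H]([C@H](O)CCCCCCCCCCNC(=O)c2cncs2)O1` gives 100000 nM in this assay, and compound 3 `CCCCCCCCCCCC[C@@H](O)[C@H]1CC[C@H]([C@H](O)CCCCCCCCCCNC(=O)c2ccsc2)O1` gives 100000 nM. Compound 1 thus stands level with compounds 2 and 3 on the digits shown: the step of no change at the digits printed from compound 1 to compound 2 (within the scatter) and the step of no change at the digits printed from compound 1 to compound 3 (within the scatter) show nothing beyond the scatter, and the same holds for no change at the digits printed from compound 2 to compound 3 (within the scatter).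

Compound 4 `CCCCCCCCCCCC[C@@H](O)[C@H]1CC[C@H]([C@H](O)CCCCCCCCCCNC(=O)c2ccnn2C)O1` has not yet been measured in this assay. Its difference from compound 1 is 1-methyl-1H-pyrazol-5-yl in place of furan-3-yl on a carbonyl carbon. All three measured steps bear on this change: each of them exchanges one five-membered aromatic ring for another on the carbonyl carbon, and none of them moved the read-out at the digits shown. Nothing in the measured set separates one heteroaryl amide from another here, so a move beyond the scatter is not expected for this exchange either. For compound 4 the expected step is no change at the digits printed from compound 1 to compound 4 (within the scatter). Compound 4 is therefore estimated to give about 100000 nM in this assay, with a range from 50000 nM to 200000 nM.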

Compound 4, concentration for 50% growth inhibition: 100000 nM
Compound 4: the middle estimate sits on the measured number at the digits printed; measured number inside the range.
By their numbers in this assay, from the lowest: compounds 1, 2, 3 and 4 (each within the scatter of the next).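

In this assay, the set now reaches a ring carrying a methyl group: exchanging the furan-3-yl ring of the amide for the 1-methyl-1H-pyrazol-5-yl ring, with 6 heavy atoms against 5 and 2 hydrogen-bond acceptors against 1, gives no change at the digits printed from compound 1 to compound 4 (within the scatter) as the step. The comparisons with the two sulfur-containing rings read the same, with no change at the digits printed from compound 3 to compound 4 (within the scatter) and no change at the digits printed from compound 2 to compound 4 (within the scatter) as their steps, so the methyl-bearing ring does not separate from the three rings without a methyl group. No supporting evidence is available to account for this flat result.

With compound 4 at 100000 nM ( the same printed number as the other three compounds ), the four amides give no read on whether any change at this position can shift the number in this assay. Still open, on these data alone, is whether a pyridin-3-yl ring, a phenyl ring bearing an amine or a carboxylic acid, or a longer chain in the shared core would move the number away from this shared value.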